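This account rests on a few compounds, and the source may have more. Where it says the series, first, only, none or still open, it means among the compounds named here.

Working notes on the series. Of the compounds shown here, three have been measured in a functional assay on A549 cells (Homo sapiens) for cytotoxicity, read by WST assay, with a stated time of 48 h; a higher number here means a weaker inhibitor, a lower number a stronger inhibitor. Compound 1 `CC(C)C[C@]1(O)NC(=O)[C@]2(OC(Cc3ccccc3)=CC2=O)[C@H]1O` returns only the limit of the assay, > 100000 nM. Compound 3 `CC(C)CC(=O)[C@@H]1O[C@@]12C(=O)C=C(Cc1ccccc1)NC2=O` likewise gives only a limit, > 100000 nM. Compound 2 `Cc1cc2c(c(=O)[nH]1)OC(C(=O)CC(C)C)O2` also comes back at a limit, > 100000 nM. So compound 2 stands where every value so far stands: at the assay limit, with no number that would place it above or below compound 1 or compound 3, all three sharing the same position (the limit of > 100000 nM in this assay, at which 3 of the 3 values shown sit).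

Compound 4 `CC(C)CC(=O)C1Oc2cc(Cc3ccccc3)[nH]c(=O)c2O1` is not yet measured. It differs from compound 2 in one place (phenyl in place of hydrogen on a saturated chain carbon bound to an aromatic carbon); cut one bond further out, the change reads methyl to benzyl. Compound 1 and compound 3 already carry a benzyl group and still return only limits, so a benzyl group has not yet carried any member of the series to a measurable value. For the measured compounds named here, no step between measured compounds exists to size this change, and the three limits give no direction. The expected step in this assay is therefore a step that the limit leaves unreadable from compound 2 to compound 4, that is, none beyond the scatter. Compound 4 is estimated at 150000 nM, between 50000 nM and 500000 nM, most likely reported as a limit rather than a number.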

Compound 4, half-maximal inhibitory concentration: > 100000 nM
Compound 4 ended at the assay's limit; the forecaster's own chance of this, stated with the estimate: 85%; the middle value is on the limit's open side.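

Compound 4 gives > 100000 nM, which is a limit and not a number. For the compounds shown here, compound 2 also stands at a limit, so no step from compound 2 to compound 4 can be read, and the phenyl in place of hydrogen has no readable size: the limit of > 100000 nM in this assay, at which 4 of the 4 values shown sit. The compounds shown leave open whether any member of the series reaches a measurable value.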